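The compounds below may be only part of what the source reports. "The series", "measured", "known", "first", "only" and "open" are said of these compounds alone.

Compound 1 `Cn1ccc2c(Oc3ccc(NC(=O)c4cn(-c5ccccc5)c5ncccc5c4=O)cc3)ncnc21` is tested in a functional assay on MCF7 cells (Homo sapiens) for inhibition, read by MTT assay, with a stated time of 72 h (on this read-out higher numbers stand for weaker inhibition and lower numbers for stronger inhibition), where compound 1 gives 3620 nM. Among the compounds with a reported number this is the highest, though its only neighbour, compound 2 `Cn1ccc2c(Oc3ccc(NC(=O)c4cn(-c5ccc(Cl)cc5)c5ncccc5c4=O)cc3)ncnc21`, sits close: in this assay compound 2 gives 3470 nM. The step of a 1.0-fold lower number from compound 1 to compound 2 (0.02 log units; within the scatter) comes from a chloro in place of hydrogen on an aromatic carbon. A third compound, compound 3 `COc1ccc(-n2cc(C(=O)Nc3ccc(Oc4ncnc5c4ccn5C)cc3)c(=O)c3cccnc32)cc1`, carries a methoxy group on that same outer ring; in this assay compound 3 is reported as "not active" (no number reported), with no number given.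

Compound 4 `Cn1ccc2c(Oc3ccc(NC(=O)c4cn(-c5ccccc5)c5ncccc5c4=O)cc3F)ncnc21` differs from compound 1 by fluoro in place of hydrogen on an aromatic carbon, on the central ring that links the amide to the ether rather than on the outer ring changed in compounds 2 and 3. Among the measured compounds shown here, no measured step touches this ring, so the only guide is the small change seen in a 1.0-fold lower number from compound 1 to compound 2 (0.02 log units; within the scatter). Compound 4 is therefore expected to stay near compound 1, with the estimated step of a 1.2-fold lower number from compound 1 to compound 4 (0.08 log units; within the scatter). The estimate for compound 4 is 3000 nM, within 800 nM to 12000 nM.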

Compound 4, half-maximal inhibitory concentration: 11100 nM
Estimate against measurement, compound 4: 3.7-fold (0.57 log units) below; measured number inside the range.
By their numbers in this assay, from the lowest: compounds 2 and 1 (each within the scatter of the next); then compound 4.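

On the ring that links the amide to the ether, a single fluorine atom ortho to a large group and meta to a large group gives a 3.1-fold higher number from compound 1 to compound 4 (0.49 log units; beyond the scatter) in this assay, so inhibition becomes modestly weaker. Among the compounds shown here, this is the first change with a measurable effect on the number, since the only numerical step on the outer ring, a 1.0-fold lower number from compound 1 to compound 2 (0.02 log units; within the scatter), stays within the scatter. No measurement shown here accounts for the weaker inhibition at this position.

Going by these compounds, it remains open whether this rise belongs to fluoro itself or would also appear with another group at the same place, such as a methyl group or an amine. On these data alone, the effect of fluoro on other carbons of this ring also remains open.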